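The source may report more compounds than this note shows. Statements on the series, on what has been measured and on what is new or still open speak of the compounds shown alone.

Compound 1 `OC[C@H]1O[C@@H](n2cc(F)c3c(-c4ccco4)ncnc32)[C@H](O)[C@@H]1O` gives 1200 nM in a functional assay on HL-60 cells (Homo sapiens) for cytotoxicity, read by XTT assay, with a stated time of 3 days (a higher number here means a weaker inhibitor, a lower number a stronger inhibitor), and sits at the low end of the series, alongside compound 3 `OC[C@H]1O[C@@H](n2cc(F)c3c(-c4ccoc4)ncnc32)[C@H](O)[C@@H]1O` at 2000 nM. Compound 2 `OC[C@H]1O[C@@H](n2cc(F)c3c(-c4ccc[nH]4)ncnc32)[C@H](O)[C@@H]1O` reads 3300 nM, with a 2.8-fold higher number from compound 1 to compound 2 (0.44 log units; beyond the scatter). Compound 4 `OC[C@H]1O[C@@H](n2cc(F)c3c(-c4ccsc4)ncnc32)[C@H](O)[C@@H]1O` carries thiophen-3-yl in place of furan-2-yl on an aromatic carbon. No thiophene has been measured in this series. The closest measured change is the furan-3-yl swap, a 1.7-fold higher number from compound 1 to compound 3 (0.22 log units; within the scatter). The pyrrole step is the only one beyond the scatter, and it stays modest. A small upward step in this assay is therefore expected, hardly beyond the scatter. The expected step is a 1.5-fold higher number from compound 1 to compound 4 (0.18 log units; within the scatter). For compound 4 the estimated value is 1800 nM, with an expected range of 750 nM to 4300 nM.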

Compound 4, half-maximal inhibitory concentration: 4900 nM
Beside the measured number, compound 4's estimate is 2.7-fold (0.43 log units) below it; the measured number lies above the stated range.
By their numbers in this assay, from the lowest: compounds 1, 3, 2 and 4 (each within the scatter of the next, the first and the last beyond it).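

At this aromatic carbon, sulfur in the five-membered ring gives the first clear shift among the neutral ring swaps: thiophen-3-yl for furan-2-yl gives (a 4.1-fold higher number from compound 1 to compound 4 (0.61 log units; beyond the scatter)), and with the attachment kept, thiophen-3-yl for furan-3-yl gives (a 2.5-fold higher number from compound 3 to compound 4 (0.39 log units; beyond the scatter)). The thiophen-3-yl and 1H-pyrrol-2-yl groups remain close, with (a 1.5-fold higher number from compound 2 to compound 4 (0.17 log units; within the scatter)). No evidence is available to explain these steps.

As far as these compounds go, whether thiophen-2-yl would track compound 4 or compound 1 remains open, which leaves attachment within the thiophene unresolved. From the compounds shown here alone, how phenyl or an amine on this carbon would read in this assay also remains open.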